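Swapping the Fluorinated Ring on a Nitro-Styryl Ketone

This account rests on a few compounds, and the source may have more. Where it says the series, first, only, none or still open, it means among the compounds named here.

Measured compounds:
compound 1 `O=C(/C(=C\c1ccc([N+](=O)[O-])c(O)c1)SCc1ccc(Br)cc1)c1c(F)c(F)c(F)c(F)c1F`: 10000 nM
compound 2 `O=C(/C(=C\c1ccc([N+](=O)[O-])c(O)c1)Sc1ccc(Br)cc1)c1c(F)c(F)c(F)c(F)c1F`: 1000 nM

In a functional assay on DU-145 cells (Homo sapiens) for inhibition, read by trypan blue exclusion, with a stated time of 96 h (on this read-out lower numbers stand for stronger inhibition of growth and higher numbers for weaker inhibition of growth), compound 1 gives 10000 nM, the highest of the two numbers; compound 2 sits at 1000 nM, and a 10-fold lower number from compound 1 to compound 2 (1.00 log units; beyond the scatter). Compound 3 `O=C(/C(=C\c1ccc([N+](=O)[O-])c(O)c1)SCc1ccc(Br)cc1)c1ccc(C(F)(F)F)cc1` is not yet measured. It differs from compound 1 at the carbonyl carbon: 4-(trifluoromethyl)phenyl in place of 2,3,4,5,6-pentafluorophenyl on a carbonyl carbon. For the measured compounds named here, the only measured step changes the group on the sulfur, not the ring on the carbonyl, so no measured step bears on this change, and nothing here points in either direction. The estimate for compound 3 is therefore no step beyond the scatter, no change at the digits printed from compound 1 to compound 3 (within the scatter), giving an expected value of 10000 nM with a range from 3000 nM to 30000 nM.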

Compound 3, concentration for 50% growth inhibition: 1000 nM
For compound 3 the middle estimate is 10-fold (1.00 log units) above the measured one; measured number below the stated range.
By their numbers in this assay, from the lowest: compounds 2 and 3 (each within the scatter of the next); then compound 1.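

On the carbonyl carbon, in this assay, 4-(trifluoromethyl)phenyl in place of 2,3,4,5,6-pentafluorophenyl gives a 10-fold lower number from compound 1 to compound 3 (1.00 log units; beyond the scatter) and so lies beyond the scatter. This position therefore affects the read-out, just as the group on the sulfur does. No measurement offered here explains the step.

Going by these compounds, whether the same ring swap would change the number for compound 2 remains open. Also open, on these data alone, is what an unsubstituted phenyl ring or a pyridine ring would do on the carbonyl carbon.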